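Chloro for methyl in the series: working notes

The source may report more compounds than this note shows. Statements on the series, on what has been measured and on what is new or still open speak of the compounds shown alone.

Measured in a functional assay on CNS cells (Homo sapiens) for antiproliferative activity; a higher number here means a weaker inhibitor of growth, a lower number a stronger inhibitor of growth:
- compound 1 `Cc1cn2c(/C=N/NC(=N)N)c(-c3ccncc3)nc2s1`: 30900 nM
- compound 2 `Cc1cn2c(/C=N/NC(=N)N)c(-c3cccnc3)nc2s1`: 28200 nM
- compound 3 `Cc1sc2nc(-c3ccccn3)c(/C=N/NC(=N)N)n2c1C`: 41700 nM

The value of compound 2 lies within the scatter of those of compound 1 and compound 3, so the three read as level. Compound 4 `N=C(N)N/N=C/c1c(-c2cccnc2)nc2sc(Cl)cn12` departs from compound 2 by one change: chloro in place of methyl on an aromatic carbon. This is chloro in place of methyl on an aromatic carbon, next to the ring sulfur. For the measured compounds named here, no measured step covers this place. Going by the values given here, the only step available, a 1.1-fold lower number from compound 1 to compound 2 (0.04 log units; within the scatter), is pyridin-3-yl in place of pyridin-4-yl and stays within the scatter. On these data alone, no shift beyond the scatter is therefore expected in this assay, and the direction stays open. The expected step is a 1.1-fold lower number from compound 2 to compound 4 (0.04 log units; within the scatter). Compound 4 is estimated at 26000 nM, with an expected range of 11000 nM to 55000 nM.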

Compound 4, concentration for total growth inhibition: 31600 nM
Beside the measured number, compound 4's estimate is 1.2-fold (0.08 log units) below it; the range from low to high includes it.
By their numbers in this assay, from the lowest: compounds 2, 1, 4 and 3 (each within the scatter of the next).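

In this assay, for the compounds shown here, chloro in place of methyl on an aromatic carbon, next to the ring sulfur, gives a 1.1-fold higher number from compound 2 to compound 4 (0.05 log units; within the scatter) and this is the only measured step at this position. Methyl and chloro therefore read as level here, with the pyridin-3-yl group held constant. No evidence on hand bears on this result.

Open, on these data alone, is whether an amine or a carboxylic acid at this position would move the number beyond the scatter. Also open, as far as these compounds go, is whether chloro reads the same alongside pyridin-4-yl.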